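The compounds below may be only part of what the source reports. "The series", "measured", "known", "first", "only" and "open" are said of these compounds alone.

In an assay on HEK293 cells for displacement of a labelled ligand from D(4) dopamine receptor (Homo sapiens), read by scintillation counting, with a stated time of 60 min (on this read-out higher numbers stand for weaker inhibition and lower numbers for stronger inhibition), compound 3 `Cc1cccc(NC(=O)CN2CCN(c3ncccn3)CC2)c1` gives 318 nM, the lowest of the three numbers; compound 1 `O=C(CN1CCN(c2ccccn2)CC1)Nc1cccnc1` gives 6410 nM and compound 2 `O=C(CN1CCN(c2ccccn2)CC1)Nc1cncnc1` gives 39300 nM. Compound 4 `Cc1cccc(NC(=O)CN2CCN(c3ccccn3)CC2)c1` differs from compound 3 by pyridin-2-yl in place of pyrimidin-2-yl on an amine nitrogen in a ring. Within the data shown here, no measured step touches the amine nitrogen in a ring: the only step, a 6.1-fold higher number from compound 1 to compound 2 (0.79 log units; beyond the scatter), sits on the amide-type nitrogen and bears on it only loosely, while compound 1 and compound 3 differ at two places and cannot be separated. A step of at most modest size is therefore expected, in either direction, a 1.3-fold lower number from compound 3 to compound 4 (0.10 log units; within the scatter). Compound 4 is estimated at 250 nM, within 60 nM to 1000 nM.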

Compound 4, inhibition constant: 212 nM
Compound 4: middle estimate off by 1.2-fold (0.07 log units), on the high side; the range from low to high includes it.
By their numbers in this assay, from the lowest: compounds 4 and 3 (each within the scatter of the next); then compound 1; then compound 2.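

Exchanging pyrimidin-2-yl for pyridin-2-yl on the amine nitrogen in a ring does not separate the two groups: a 1.5-fold lower number from compound 3 to compound 4 (0.18 log units; within the scatter) stays within the scatter. With pyridin-2-yl held constant, the group on the amide-type nitrogen carries the large changes, as a 190-fold lower number from compound 2 to compound 4 (2.27 log units; beyond the scatter) and a 30-fold lower number from compound 1 to compound 4 (1.48 log units; beyond the scatter) are both beyond the scatter.

Going by these compounds, it remains open whether a phenyl or 3-chlorophenyl on the amide-type nitrogen would give numbers as low as 3-methylphenyl, and whether a piperidine ring would be tolerated on the amine nitrogen. No available evidence explains these steps.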